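From a Hydrazide Urea to an Aryl Urea

The compounds below may be only part of what the source reports. "The series", "measured", "known", "first", "only" and "open" are said of these compounds alone.

Measured so far:
compound 1, `CCOC(=O)NC(c1ccccc1)c1ccc(Cl)cc1`: 21%
compound 2, `COc1cc(NC(C)CCCNC(=O)NCCNC(c2ccccc2)(c2ccccc2)c2ccccc2)c2ncccc2c1`: 89%
compound 3, `COc1cc(NC(C)CCCNC(=O)NNC(=O)N(CCO)CCO)c2ncccc2c1`: 43%

Three compounds have been run in a physicochemical assay for inhibition, read by spectrophotometry, tested at 100 uM; on this read-out higher numbers stand for more inhibition at the one concentration tested (going by the name of the read-out) and lower numbers for less inhibition. Compound 3 stands second highest of the three. Its nearest neighbour is compound 1, which gives a lower number by a gap beyond the scatter, while compound 2 gives a higher number by a gap that also lies beyond the scatter. Compound 4, `COc1cc(NC(C)CCCNC(=O)Nc2ccc(Cl)c(C(F)(F)F)c2)c2ncccc2c1`, has not yet been measured. It differs from compound 3 by 4-chloro-3-(trifluoromethyl)phenyl in place of (bis(2-hydroxyethyl)carbamoyl)amino on an amide-type nitrogen. For the measured compounds named here, no step between two measured compounds is available for comparison, so the expectation rests on the values themselves, chiefly on compound 2, which gives 89%. An upward step beyond the scatter is expected, estimated at a number 27 percentage points higher from compound 3 to compound 4 (beyond the scatter). Compound 4 is therefore estimated at 70%, within a range from 50% to 90%.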

Compound 4, a percentage reported as inhibition, at one concentration (the size of the read-out at that concentration, not a potency): 61%
The estimate for compound 4 lay 9 percentage points above the measured number; the range from low to high includes it.
By their numbers in this assay, from the lowest: compound 1; then compound 3; then compound 4; then compound 2.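

For the compounds shown here, on the amide-type nitrogen, 4-chloro-3-(trifluoromethyl)phenyl in place of (bis(2-hydroxyethyl)carbamoyl)amino gives the first comparison at a single place in this assay, a modest step of a number 18 percentage points higher from compound 3 to compound 4 (beyond the scatter). At this position, then, an aromatic ring of carbon only, with no hydrogen-bond donors or acceptors, stands where a ringless group carrying both had been, and inhibition does not fall. Nothing measured here accounts for the step. Going by these compounds, the shares of the ring, the chlorine and the trifluoromethyl remain open, since the whole group changes at once. On these data alone, how an unsubstituted phenyl or a benzyl group would read on this nitrogen also remains open.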